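This account rests on a few compounds, and the source may have more. Where it says the series, first, only, none or still open, it means among the compounds named here.

Values in a functional assay on A2780 cells (Homo sapiens) for inhibition, with a stated time of 72 h; on this read-out higher numbers stand for weaker inhibition and lower numbers for stronger inhibition:
- compound 1 `CN1c2ccc(NC(=S)Nc3ccc([N+](=O)[O-])cc3)cc2C(C)(C)C(=O)C1(C)C`: 4400 nM
- compound 2 `CN1c2ccc(NC(=O)Nc3ccc(C(F)(F)F)cc3)cc2C(C)(C)C(=O)C1(C)C`: 2580 nM
- compound 3 `CN1c2ccc(NC(=S)Nc3ccc(OC(F)(F)F)cc3)cc2C(C)(C)C(=O)C1(C)C`: 5400 nM

Compound 2 gives 2580 nM, within the scatter of compound 1 and just beyond the scatter on the lower side of compound 3.

Compound 4 `CN1c2ccc(NC(=O)Nc3ccc(N)cc3)cc2C(C)(C)C(=O)C1(C)C` is the next to read. The change is amino in place of trifluoromethyl on an aromatic carbon.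

For the measured compounds named here, only one measured step touches a group at this place: a 1.2-fold higher number from compound 1 to compound 3 (0.09 log units; within the scatter). That swap of nitro for trifluoromethoxy stayed within the scatter, which gives weak support for a small effect here. Going by the values given here, it is indirect evidence, since that pair carries a thiocarbonyl where compound 2 and compound 4 have a carbonyl, and no amino compound has been measured.

The expected step is a 1.2-fold higher number from compound 2 to compound 4 (0.09 log units; within the scatter), probably not beyond the scatter, with a slight lean towards a higher number. For compound 4 the estimate is 3200 nM, with an expected range of 1100 nM to 9000 nM.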

Compound 4, half-maximal inhibitory concentration: 7700 nM
Estimate against measurement, compound 4: 2.4-fold (0.38 log units) below, and the stated range covers the measured number.
By their numbers in this assay, from the lowest: compounds 2, 1, 3 and 4 (each within the scatter of the next, the first and the last beyond it).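

In this assay, for the compounds shown here, the change from 4-(trifluoromethyl)phenyl to 4-aminophenyl gives the only step at this position that lies beyond the scatter (a 3.0-fold higher number from compound 2 to compound 4 (0.47 log units; beyond the scatter)), while the swap of nitro for trifluoromethoxy in the thiocarbonyl pair stayed within it (a 1.2-fold higher number from compound 1 to compound 3 (0.09 log units; within the scatter)). The group on this aromatic carbon can therefore shift the number in the carbonyl compounds, with amino on the weaker side of trifluoromethyl, though this rests on a single pair. No measurement shown here accounts for the size or direction of this step.

Still open, from the compounds shown here alone, is how a nitrile, a carboxylic acid or a methylamino group would read on this aromatic carbon. The shown compounds also include no pair that shares a substituent and differs only in carbonyl against thiocarbonyl, so that exchange stays unresolved.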